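Swapping naphthalen-1-yl for 3,4-dimethoxyphenyl: an expected gain

The source may hold more compounds than are shown below. What is called first, only, known or untested is meant among the compounds shown, and "the series" means these compounds.

In a functional assay on THP-1 cells (Homo sapiens) for inhibition, read by sulforhodamine B assay, with a stated time of 48 h, tested at 50 uM (on this read-out lower numbers stand for less inhibition of growth and higher numbers for more inhibition of growth at the one concentration tested), compound 1 (`COc1cc(/C=C/C(=O)/C=C/c2cccc3ccccc23)ccc1OCc1cn(CCCOc2cc(=O)oc3ccccc23)nn1`) gives 71%, the lowest of the three numbers. Compound 2 (`COc1cc(/C=C/C(=O)/C=C/c2cc(OC)c(OC)c(OC)c2)ccc1OCc1cn(CCOc2cc(=O)oc3ccccc23)nn1`) gives 99%, and compound 3 (`COc1ccc(/C=C/C(=O)/C=C/c2ccc(OCc3cn(CCOc4cc(=O)oc5ccccc45)nn3)c(OC)c2)cc1OC`) gives 90%. Unmeasured compound 4 (`COc1ccc(/C=C/C(=O)/C=C/c2ccc(OCc3cn(CCCOc4cc(=O)oc5ccccc45)nn3)c(OC)c2)cc1OC`) departs from compound 1 as follows: 3,4-dimethoxyphenyl in place of naphthalen-1-yl on a double-bonded chain carbon bound to a double-bonded chain carbon. For the measured compounds named here, the one measured step, a number 9 percentage points lower from compound 2 to compound 3 (within the scatter), puts hydrogen in place of methoxy and so bears only loosely on this change. More telling is compound 3, which already carries 3,4-dimethoxyphenyl and reaches 90%, beyond the scatter from compound 1. A rise somewhat smaller than that gap is therefore expected in this assay. The expected step is a number 14 percentage points higher from compound 1 to compound 4 (beyond the scatter). For compound 4 the estimate is 85%, with an expected range of 70% to 99%.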

Compound 4, percent growth inhibition at one concentration: 73%
The estimate for compound 4 lay 12 percentage points above the measured number; low and high end bracket the measured number.
By their numbers in this assay, from the lowest: compounds 1 and 4 (each within the scatter of the next); then compounds 3 and 2 (each within the scatter of the next).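

In this assay, this change on a double-bonded chain carbon bound to a double-bonded chain carbon shifts the number little, a number 2 percentage points higher from compound 1 to compound 4 (within the scatter), so naphthalen-1-yl and 3,4-dimethoxyphenyl are not told apart here. The high number of compound 3, 90%, does not carry over to compound 4, which shares its 3,4-dimethoxyphenyl but not its chain and gives 73%. No evidence at hand explains this result.

Whether the chain alone accounts for that gap remains open. So does how a phenyl bearing a carboxylic acid or a dimethylamino group would read at this place.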